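The source may report more compounds than this note shows. Statements on the series, on what has been measured and on what is new or still open speak of the compounds shown alone.

- compound 1 `O=C(CCCCC1CCSS1)Nc1ccccn1`: 2.61%
- compound 2 `O=C(CCCCC1CCSS1)Nc1ccc(Cl)cn1`: 3.93%
- compound 3 `O=C(CCCCC(S)CCS)Nc1ccccn1`: 5.01%

These numbers come from a functional assay on NCI-H460 cells (Homo sapiens) for inhibition, read by MTT assay, with a stated time of 24 h, tested at 0.1 ug/mL; a higher number here means more inhibition of growth at the concentration tested, a lower number less inhibition of growth. In this set, compound 3 gives 5.01%, which lies within the scatter of the numbers for compound 1 and compound 2, so the three cannot be ranked.

Compound 4 `O=C(CCCCC(S)CCS)Nc1ccc(Cl)cn1` departs from compound 3 by a single change, chloro in place of hydrogen on an aromatic carbon. One measured step makes the same exchange, a number 1.3 percentage points higher from compound 1 to compound 2 (within the scatter), though on the compound that retains the five-membered non-aromatic ring. The other measured step, a number 2.4 percentage points higher from compound 1 to compound 3 (within the scatter), replaces that ring with an open group and bears on the exchange only indirectly. Neither step leaves the scatter, so no change beyond the scatter is expected here, and the direction cannot be called with any confidence. The estimate is a number 1.5 percentage points higher from compound 3 to compound 4 (within the scatter), a small expected step. Compound 4 is expected at 6.5%, with an estimated range of 1% to 16%.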

Compound 4, percent growth inhibition at one concentration: "not active" (no number reported)
Nothing numeric was reported for compound 4; there is nothing to compare the estimate with.
By their numbers in this assay, from the lowest: compounds 1, 2 and 3 (each within the scatter of the next).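

For the compounds shown here, compound 4 is recorded in this assay as "not active", without a number, so no step from compound 3 to compound 4 can be read. Nothing given here accounts for that entry. The compounds shown leave open what chloro in place of hydrogen does to growth inhibition in the open-chain compounds.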